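This account rests on a few compounds, and the source may have more. Where it says the series, first, only, none or still open, it means among the compounds named here.

Measured compounds:
compound 1 `CCO/C(O)=C\c1nncc2cncn12` — in a functional assay for inhibition, with Homo sapiens as the target (a higher number here means a weaker inhibitor, a lower number a stronger inhibitor), compound 1 gives > 48000 nM
compound 2 `COCc1nc(C)c2cnnc(S)n12` — in this assay compound 2 gives > 48000 nM
compound 3 `c1ncn2c1C(NC1CCCC1)NN=C2NC1CCCC1` — in this assay compound 3 gives > 48000 nM

Each of these values is a limit of the assay, not a number. Going by the values given here, compound 1 stands at the ceiling of what this assay reports, as the limit of > 48000 nM in this assay, at which 3 of the 3 values shown sit, shows, and no compound here gives a number at all. Compound 4 `O/C(=C/c1nncc2cncn12)c1ccccc1` is not yet measured. It differs from compound 1 by phenyl in place of ethoxy on a double-bonded chain carbon bound to a double-bonded chain carbon and an oxygen on an unsaturated carbon. Among the compounds with values here, no measured pair shows how such a change plays out in this assay. The expected step from compound 1 to compound 4 is none beyond the scatter, a step that the limit leaves unreadable from compound 1 to compound 4. Compound 4 is expected to give 60000 nM, between 20000 nM and 200000 nM, most likely again as a limit.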

Compound 4, half-maximal inhibitory concentration: 38000 nM
Compound 4: the middle estimate sits 1.6-fold (0.20 log units) above what was measured, and the stated range covers the measured number.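

In this assay compound 4 is the first compound shown to give a number rather than a limit, so phenyl in place of ethoxy at this position can bring a value into the readable range. As far as these compounds go, the true size of the change stays unknown and may be no larger than the scatter (an at least 1.2-fold lower number from compound 1 to compound 4 (0.10 log units; that floor lies within the scatter)) and so says little yet about strength. The other values shown offer no number to set beside it: the limit of > 48000 nM in this assay, at which 3 of the 4 values shown sit.

From the compounds shown here alone, whether an amine, a carboxylic acid or a longer chain at this position would also give a number stays open. So does whether a benzyl group would behave as phenyl does.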